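Replacing the hydroxy group in a weak nicotinic receptor antagonist

The source may report more compounds than this note shows. Statements on the series, on what has been measured and on what is new or still open speak of the compounds shown alone.

Compound 1 `C[N+](C)(C)Cc1cn(Cc2ccc(O)cc2)c2ccccc12`: 24900 nM
Compound 2 `COc1cc(Cn2cc(C[N+](C)(C)C)c3ccccc32)ccc1O`: 9100 nM

In an assay on HEK293 cells for antagonist activity at Neuronal acetylcholine receptor; alpha4/beta2 (Homo sapiens), read by calcium flux (on this read-out higher numbers stand for weaker inhibition and lower numbers for stronger inhibition), compound 1 gives 24900 nM, the highest of the two numbers measured; its nearest neighbour is compound 2, and the step of a 2.7-fold lower number from compound 1 to compound 2 (0.44 log units; beyond the scatter) comes from a methoxy in place of hydrogen on an aromatic carbon. Compound 3 `C[N+](C)(C)Cc1cn(Cc2ccc([N+](C)(C)C)cc2)c2ccccc12` differs from compound 1 by a group of 4 heavy atoms (3 carbon, 1 nitrogen; no ring) in place of one oxygen atom, on an aromatic carbon. Going by the values given here, no measured step covers this exchange, so the only measured step offers no direct guide, and a step of either direction in this assay is conceivable. Compound 3 is therefore expected to stay near compound 1, with a 1.2-fold lower number from compound 1 to compound 3 (0.10 log units; within the scatter) and a wide range: 20000 nM (from 5000 nM to 80000 nM).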

Compound 3, half-maximal inhibitory concentration: 20000 nM
Estimate against measurement, compound 3: no gap at the digits printed; the measured number falls inside the stated range.
By their numbers in this assay, from the lowest: compound 2; then compounds 3 and 1 (each within the scatter of the next).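

At this place on the ring, swapping the hydroxy group for a group of 4 heavy atoms with a net charge of +1 and no hydrogen-bond donors or acceptors gives only a 1.2-fold lower number from compound 1 to compound 3 (0.10 log units; within the scatter) in this assay. The hydrogen-bond donor and acceptor of the hydroxy group are therefore not required to hold the number at this level. Nothing available explains why so different a group leaves the reading within the scatter. Going by these compounds, whether an amine or a carboxylic acid at this place would also leave the number unchanged remains open.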